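The compounds below may be only part of what the source reports. "The series", "measured", "known", "first", "only" and "open" are said of these compounds alone.

Of the compounds shown here, three have been measured in a functional assay on A-431 cells (Homo sapiens) for cytotoxicity, read by MTT assay, with a stated time of 48 h; on this read-out lower numbers stand for stronger inhibition and higher numbers for weaker inhibition. Going by the values given here, compound 1 `CCCCCCCCCCCCCCNC(=O)[C@@H](N)[C@@H](C)O` gives 14600 nM, compound 2 `CCCCCCCCCCCCCCCCCCNC(=O)[C@@H](N)[C@@H](C)O` gives 21300 nM, and the step of a 1.5-fold higher number from compound 1 to compound 2 (0.16 log units; within the scatter) is the only one-change step among them. Compound 3 `CCCCCCCCNC(=O)[C@@H](NC(=O)c1ccccc1)[C@@H](C)O` gives 61300 nM, the highest of the three numbers and beyond the scatter from both others, so it is the weakest inhibitor here. Compound 4 `CCCCCCCCNC(=O)[C@@H](NC(=O)c1ccco1)[C@@H](C)O` differs from compound 3 by furan-2-yl in place of phenyl on a carbonyl carbon. Among the compounds with values here, no measured step touches an aromatic ring; the single step known is a chain lengthening, so nothing in the data bears on this change. The expected outcome is therefore a step of a 1.0-fold lower number from compound 3 to compound 4 (0.01 log units; within the scatter), staying within the scatter. Compound 4 is expected to give 60000 nM, between 25000 nM and 150000 nM.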

Compound 4, half-maximal inhibitory concentration: 64500 nM
Compound 4: middle estimate off by 1.1-fold (0.03 log units), on the low side; measured number inside the range.
By their numbers in this assay, from the lowest: compounds 1 and 2 (each within the scatter of the next); then compounds 3 and 4 (each within the scatter of the next).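

In this assay, going by these compounds alone, the step of a 1.1-fold higher number from compound 3 to compound 4 (0.02 log units; within the scatter) is the first measured change to the ring on this carbonyl carbon, and it lies within the scatter. Furan-2-yl, with its ring oxygen and hydrogen-bond acceptor, therefore gives a number that cannot be told apart from that of phenyl at this position. No available evidence accounts for this result. Still open, going by these compounds, is whether another group here, such as pyridin-3-yl or a simple methyl, would move the number beyond the scatter. Also open, on these data alone, is whether furan-2-yl and phenyl would still match on a longer chain.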